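A few compounds are considered here, and "the series" means these few. Any claim that something is new, unique, unknown or untested is made for them only; others in the source may bear on it.

Three related compounds have been tested in a functional assay on MDA-MB-231 cells (Homo sapiens) for antiproliferative activity, read by MTT assay, with a stated time of 72 h; a lower number here means a stronger inhibitor, a higher number a weaker inhibitor. Compound 1 `CC1=CC[C@H]2[C@@H]1CC=C(C)[C@@H](CCC1=C(C)CC[C@@H]3OC(C)(C)[C@@H](O)CC[C@@]13C)C2(C)C` gives only a limit in this assay, > 50000 nM. Compound 2 `CC(=O)O[C@H]1CC[C@]2(C)[C@H](CC[C@@](C)(O)[C@H]2CC[C@@H]2C(C)=CC[C@H]3[C@H](CC[C@]3(C)O)C2(C)C)OC1(C)C` gives 38000 nM, the highest of the two numbers shown. Within the data shown here, compound 3 `CC1=CC[C@H]2[C@H](CC[C@]2(C)O)C(C)(C)[C@@H]1CC[C@H]1[C@]2(C)CC[C@H](OC(=O)c3ccccc3)C(C)(C)O[C@H]2CC[C@@]1(C)O` gives 16100 nM, and the step of a 2.4-fold lower number from compound 2 to compound 3 (0.37 log units; beyond the scatter) is the one measured change that bears on what follows.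

Compound 4 `CC1=CC[C@H]2[C@H](CC[C@]2(C)O)C(C)(C)[C@@H]1CC[C@H]1[C@]2(C)CC[C@H](OC(=O)c3ccc(Cl)cc3)C(C)(C)O[C@H]2CC[C@@]1(C)O` differs from compound 2 in one place: 4-chlorophenyl in place of methyl on a carbonyl carbon. This closely resembles the change that gave the modest drop from compound 2 to compound 3, so a step of similar size, downward and beyond the scatter, is expected. For compound 4 the expected value in this assay is 14000 nM, with a range from 6000 nM to 32000 nM, which means an expected step of a 2.7-fold lower number from compound 2 to compound 4 (0.43 log units; beyond the scatter).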

Compound 4, half-maximal inhibitory concentration: 10300 nM
The estimate for compound 4 lay 1.4-fold (0.13 log units) above the measured number, within the range that was stated.
By their numbers in this assay, from the lowest: compounds 4 and 3 (each within the scatter of the next); then compound 2. At a limit, above all of these: compound 1.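

In this assay, the change from acetyl to (4-chlorophenyl)carbonyl gives a 3.7-fold lower number from compound 2 to compound 4 (0.57 log units; beyond the scatter), so the drop first seen with phenyl appears a second time at this position. Chloro in place of hydrogen on the aromatic carbon gives a 1.6-fold lower number from compound 3 to compound 4 (0.19 log units; within the scatter), which means that compound 3 and compound 4 cannot be told apart here, and the chloro shows no effect of its own.

As far as these compounds go, whether an amine or a carboxylic acid on that aromatic ring, or a longer chain in its place, would shift the number remains open. Nothing shown here explains why these two aromatic groups give lower numbers than methyl.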